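Moving a hydroxyl on a triarylpyridine: same swap, new position

The source may report more compounds than this note shows. Statements on the series, on what has been measured and on what is new or still open speak of the compounds shown alone.

Compound 1 `Oc1ccc(-c2cc(-c3ccc(O)cc3)nc(-c3ccc(O)cc3)c2)cc1` is one of three closely spaced measurements. In a functional assay on T47D cells (Homo sapiens) for cytotoxicity, read by CCK-8 assay, with a stated time of 4 days (a higher number here means a weaker inhibitor, a lower number a stronger inhibitor), compound 1 gives 4270 nM. Compound 2 `Oc1ccc(-c2cc(-c3cccc(O)c3)cc(-c3ccc(O)cc3)n2)cc1` gives 4070 nM, and compound 3 `Oc1ccc(-c2cc(-c3ccccc3O)cc(-c3ccc(O)cc3)n2)cc1` gives 5350 nM; the step of a 1.0-fold lower number from compound 1 to compound 2 (0.02 log units; within the scatter) and the step of a 1.3-fold higher number from compound 1 to compound 3 (0.10 log units; within the scatter) both stay within the scatter, as does a 1.3-fold higher number from compound 2 to compound 3 (0.12 log units; within the scatter), so none of the three can be told apart on potency.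

Compound 4 `Oc1ccc(-c2cc(-c3ccc(O)cc3)nc(-c3cccc(O)c3)c2)cc1` differs from compound 1 by 3-hydroxyphenyl in place of 4-hydroxyphenyl on an aromatic carbon. Within the data shown here, the only measured step with the same change of group, a 1.0-fold lower number from compound 1 to compound 2 (0.02 log units; within the scatter), was flat, although there the swap sat at a different place on the shared core. Nothing measured here separates the two places, so the same outcome is the only supported expectation. Compound 4 is therefore expected to show essentially no shift, a 1.0-fold higher number from compound 1 to compound 4 (0.00 log units; within the scatter), in this assay. The estimate for compound 4 is 4300 nM, with a range from 2000 nM to 9500 nM.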

Compound 4, half-maximal inhibitory concentration: 4470 nM
Beside the measured number, compound 4's estimate is 1.0-fold (0.02 log units) below it; the range from low to high includes it.
By their numbers in this assay, from the lowest: compounds 2, 1, 4 and 3 (each within the scatter of the next).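

In this assay, the step of a 1.0-fold higher number from compound 1 to compound 4 (0.02 log units; within the scatter) shows that putting 3-hydroxyphenyl in place of 4-hydroxyphenyl next to the ring nitrogen leaves the number within the scatter. Until now this change had been seen only at a different place on the shared core, in the step of a 1.0-fold lower number from compound 1 to compound 2 (0.02 log units; within the scatter), so the same swap now reads as flat at two places rather than one. Nothing measured here gives a reason for this flat result.

All the compounds shown carry a hydroxyl on each outer ring, so it remains open whether the number next to the ring nitrogen would move if an amine or a carboxylic acid took the place of that hydroxyl. Also open, as far as these compounds go, is whether moving the hydroxyl at both places at once would stay as flat.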